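This account rests on a few compounds, and the source may have more. Where it says the series, first, only, none or still open, it means among the compounds named here.

Working notes on the series, all read in a functional assay on A549 cells (Homo sapiens) for antiproliferative activity, read by MTT assay, with a stated time of 48 h; a higher number here means a weaker inhibitor, a lower number a stronger inhibitor. Compound 1 `COc1ccccc1-n1cc(COC(=O)/C(C)=C/CC/C(C)=C/CC/C(C)=C/CC[C@@H]2[C@@]3(C)CCC(=O)C(C)(C)[C@H]3CC[C@@]2(C)O)nn1` gives > 150000 nM, which is a limit and not a number. Compound 2 `C/C(=C\CC/C(C)=C/CC[C@@H]1[C@@]2(C)CCC(=O)C(C)(C)[C@H]2CC[C@@]1(C)O)CC/C=C(\C)C(=O)OCc1cn(-c2cccc(C)c2)nn1` gives > 150000 nM, again a limit. Compound 3 `C/C(=C\CC/C(C)=C/CC[C@@H]1[C@@]2(C)CCC(=O)C(C)(C)[C@H]2CC[C@@]1(C)O)CC/C=C(\C)C(=O)OCc1cn(-c2ccccc2C)nn1` gives > 150000 nM, also a limit. Compound 3 thus has no numeric position in the series, and the three readings sit together: the limit of > 150000 nM in this assay, at which 3 of the 3 values shown sit.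

Compound 4 `C/C(=C\CC/C(C)=C/CC[C@@H]1[C@@]2(C)CCC(=O)C(C)(C)[C@H]2CC[C@@]1(C)O)CC/C=C(\C)C(=O)OCc1cn(-c2cccc(F)c2)nn1` differs from compound 3 at one place: 3-fluorophenyl in place of 2-methylphenyl on an aromatic nitrogen. In words, 3-fluorophenyl stands in place of 2-methylphenyl on an aromatic nitrogen of the five-membered aromatic ring with 3 nitrogen, and the shared core is unchanged.

Among the measured compounds shown here, three measured steps bear on this change, since all of them alter the same phenyl group: a step that the two limits leave unreadable from compound 1 to compound 2, a step that the two limits leave unreadable from compound 1 to compound 3 and a step that the two limits leave unreadable from compound 2 to compound 3. For the measured compounds named here, none of them has a readable size, and no compound with fluorine on this phenyl group has been measured yet. No size or direction can therefore be carried over, and no shift beyond the scatter is expected. The expected step is a number no higher from compound 3 to compound 4 (the limit leaves the size open). For compound 4 the estimated value is 150000 nM, with an expected range of 70000 nM to 300000 nM, and another limit rather than a number is the likely report.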

Compound 4, half-maximal inhibitory concentration: 124000 nM
Beside the measured number, compound 4's estimate is 1.2-fold (0.08 log units) above it; low and high end bracket the measured number.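

In this assay compound 4 is the only compound shown that gives a number, 124000 nM, rather than a limit. The other readings are limits and not numbers: the limit of > 150000 nM in this assay, at which 3 of the 4 values shown sit.

Set against those limits, the change reads as an at least 1.2-fold lower number from compound 3 to compound 4 (0.08 log units; that floor lies within the scatter), as an at least 1.2-fold lower number from compound 2 to compound 4 (0.08 log units; that floor lies within the scatter) and as an at least 1.2-fold lower number from compound 1 to compound 4 (0.08 log units; that floor lies within the scatter); each of these floors lies within the scatter, and the true size of each step stays open, which means that 3-fluorophenyl on the aromatic nitrogen gives a readable value without establishing a real gain over 2-methylphenyl, 3-methylphenyl or 2-methoxyphenyl.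

The compounds shown leave open whether the number belongs to fluorine as such or to its place on the phenyl group, a question that 2-fluorophenyl, 4-fluorophenyl or 3-chlorophenyl would bear on. They also leave open whether a different kind of group on the aromatic nitrogen, such as benzyl or a phenyl group carrying an amine or a carboxylic acid, would move the reading beyond the scatter.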